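The compounds below may be only part of what the source reports. "The series", "measured", "known", "first", "only" and "open" are said of these compounds alone.

Compound 1 `CCCCCN1C(=O)C/C(=C\c2cccc(C(=O)Nc3ccc(C)cc3)c2)C1=O`: in an ADME assay on HCT-116 cells (Homo sapiens) for cytotoxicity, read by MTT assay, with a stated time of 72 h (on this read-out higher numbers stand for weaker inhibition and lower numbers for stronger inhibition), compound 1 gives > 100000 nM, which is a limit of the assay rather than a number.
Compound 2 `Cc1cccc(NC(=O)c2cccc(/C=C3\CC(=O)N(c4ccccc4)C3=O)c2)c1`: in this assay compound 2 gives > 100000 nM, again a limit.
Compound 3 `COc1ccc(NC(=O)c2cccc(/C=C3\CC(=O)N(c4ccccc4)C3=O)c2)c(C)c1`: in this assay compound 3 gives > 100000 nM, again a limit.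

Compound 1 therefore stands only at a limit, and so do the two further values; all three rest at the limit of > 100000 nM in this assay, at which 3 of the 3 values shown sit. Compound 4 `CCCCCN1C(=O)C/C(=C\c2cccc(C(=O)Nc3cccc(CC)c3)c2)C1=O` differs from compound 1 by 3-ethylphenyl in place of 4-methylphenyl on an amide-type nitrogen. Among the measured compounds shown here, the only measured step, a step that the two limits leave unreadable from compound 2 to compound 3, cannot be read in size, so no measured step bears usefully on the change to compound 4. No shift beyond the scatter is expected in this assay; most likely compound 4 also returns a limit. Compound 4 is estimated at 150000 nM, with a range from 50000 nM to 500000 nM. This estimate means an expected step that the limit leaves unreadable from compound 1 to compound 4.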

Compound 4, half-maximal inhibitory concentration: 75300 nM
For compound 4 the middle estimate is 2.0-fold (0.30 log units) above the measured one, within the range that was stated.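

In this assay, putting 3-ethylphenyl in place of 4-methylphenyl on the amide-type nitrogen gives an at least 1.3-fold lower number from compound 1 to compound 4 (0.12 log units; that floor lies within the scatter). This change therefore yields a readable number, although that floor alone does not establish a real shift. Most of the set still gives no number: the limit of > 100000 nM in this assay, at which 3 of the 4 values shown sit.

The change alters both the group and where it sits, and the compounds shown do not separate these two differences. Also open, from the compounds shown here alone, is whether a longer chain or an amine on this phenyl ring would move the number beyond the scatter.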